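Cyclopentyl on the Indole Nitrogen of Compound 1

A few compounds are considered here, and "the series" means these few. Any claim that something is new, unique, unknown or untested is made for them only; others in the source may bear on it.

Measured in an assay for inhibition of MAP kinase-interacting serine/threonine-protein kinase 2 (Homo sapiens), read by TR-FRET; a lower number here means a stronger inhibitor, a higher number a weaker inhibitor:
- compound 1 `COc1ccc(Nc2nccc(-c3c[nH]c4ccccc34)n2)c(OC)c1`: 110 nM
- compound 2 `COc1ccc(Nc2nccc(-c3sc(SCc4cccnc4)nc3C)n2)c(OC)c1`: 400 nM

Compound 1 holds the lowest of the two numbers in this assay. Its nearest neighbour is compound 2, whose number is higher by a margin that lies beyond the usual scatter of the measurement, so compound 1 stands as the stronger of the two inhibitors measured so far. Within the data shown here, the two compounds share the same anilinopyrimidine portion and differ in the group attached to the pyrimidine, for which no single-point step is available.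

Compound 3 `COc1ccc(Nc2nccc(-c3cn(C4CCCC4)c4ccccc34)n2)c(OC)c1` keeps the core of compound 1 and differs from it in one place: cyclopentyl in place of hydrogen on an aromatic nitrogen. Among the measured compounds shown here, no measured pair shows what such a change does here, so the expectation rests only on the size of the substituent and the single starting value of compound 1. A modest step is expected, more likely toward a higher number than a lower one, but possibly within the scatter. The expected step of a 1.8-fold higher number from compound 1 to compound 3 (0.26 log units; within the scatter) is therefore small. Compound 3 is expected to give 200 nM. For compound 3 the estimated range runs from 50 nM to 800 nM.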

Compound 3, inhibition constant: 390 nM
Estimate against measurement, compound 3: 2.0-fold (0.29 log units) below, within the range that was stated.
By their numbers in this assay, from the lowest: compound 1; then compounds 3 and 2 (each within the scatter of the next).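

Among these compounds, this is the first step that changes a single place, and it shows that the aromatic nitrogen of compound 1 is sensitive to substitution: in this assay, cyclopentyl in place of hydrogen gives a 3.5-fold higher number from compound 1 to compound 3 (0.55 log units; beyond the scatter). The change is modest, however, and it does not abolish inhibition, since compound 3 still gives 390 nM with a ring of five carbon atoms on that nitrogen, so this position can carry a substituent of this size at a measurable cost. Nothing measured on these compounds gives a reason for the rise in the number.

With only one substituent at this nitrogen, the compounds shown cannot separate the effect of losing the hydrogen from the effect of adding the cyclopentyl ring, and they give no trend with the size or shape of the group. A methyl group, a longer chain such as n-butyl, or a chain ending in an amine or a carboxylic acid on the same nitrogen would show whether the number stays near that of compound 1, rises further or falls.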